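Removing a Methoxy Group From a Naphthol Pyrazole Benzothiazole Series

The compounds below may be only part of what the source reports. "The series", "measured", "known", "first", "only" and "open" are said of these compounds alone.

Compound 1 `O=[N+]([O-])c1cccc(-c2nn(-c3ccccc3)cc2C(Nc2nc3ccccc3s2)c2c(O)ccc3ccccc23)c1`: 43900 nM
Compound 2 `COc1ccc2nc(NC(c3cn(-c4ccccc4)nc3-c3cccc([N+](=O)[O-])c3)c3c(O)ccc4ccccc34)sc2c1`: 26800 nM
Compound 3 `COc1cccc(-c2nn(-c3ccccc3)cc2C(Nc2nc3ccc(OC)cc3s2)c2c(O)ccc3ccccc23)c1`: 62600 nM

Of the compounds shown here, three have been measured in a functional assay on MCF7 cells (Homo sapiens) for antiproliferative activity, read by MTT assay, with a stated time of 48 h (on this read-out lower numbers stand for stronger inhibition and higher numbers for weaker inhibition), and compound 4 `COc1ccc2nc(NC(c3cn(-c4ccccc4)nc3-c3ccccc3)c3c(O)ccc4ccccc34)sc2c1` is the next to be tested. Compound 4 is derived from compound 3 by hydrogen in place of methoxy on an aromatic carbon. The same kind of change separates compound 2 from compound 1, where it is hydrogen in place of methoxy on an aromatic carbon and produced a 1.6-fold higher number from compound 2 to compound 1 (0.21 log units; within the scatter). The surroundings are not identical: in the earlier pair the ring is part of a fused or bridged system of two rings, meta to a fused ring and para to a fused ring, whereas in the new pair it is a six-membered aromatic ring of carbon only, meta to a large group. The cores of compound 2 and compound 3 differ by methoxy in place of nitro on an aromatic carbon, a change that gave a 2.3-fold higher number from compound 2 to compound 3 (0.37 log units; beyond the scatter). Because the earlier step of this kind was a 1.6-fold higher number from compound 2 to compound 1 (0.21 log units; within the scatter), a similarly small step is expected from compound 3 to compound 4, a 1.4-fold higher number from compound 3 to compound 4 (0.16 log units; within the scatter). Compound 4 is therefore estimated at 90000 nM, likely between 40000 nM and 200000 nM.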

Compound 4, half-maximal inhibitory concentration: 40800 nM
The estimate for compound 4 lay 2.2-fold (0.34 log units) above the measured number; the range from low to high includes it.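

Hydrogen in place of methoxy was read on two cores, and the two steps cannot be told apart: the same change on two cores in this assay, a 1.6-fold higher number (0.21 log units; within the scatter) from compound 2 to compound 1 and a 1.5-fold lower number (0.19 log units; within the scatter) from compound 3 to compound 4, 2.5-fold (0.40 log units) apart, within the scatter of two such steps. On the new core the step is a 1.5-fold lower number from compound 3 to compound 4 (0.19 log units; within the scatter), and hydrogen in place of nitro gives a 1.5-fold higher number from compound 2 to compound 4 (0.18 log units; within the scatter). This shows that the change left the number within the scatter on both cores, but it does not show a real effect of the methoxy group, nor that the result would hold on any other core.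

The compounds shown leave open whether a different group on the phenyl ring, such as an amine or a carboxylic acid, would move the number beyond the scatter. They also leave open whether replacing the unsubstituted phenyl on the pyrazole would do so.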